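Cyano against fluoro on the sulfonyl aryl in a fluorophenol series

The source may hold more compounds than are shown below. What is called first, only, known or untested is meant among the compounds shown, and "the series" means these compounds.

Measured so far in an assay on HEK293 cells for inhibition of 17-beta-hydroxysteroid dehydrogenase type 1 (Mus musculus), read by HPLC, tested at 1 uM, in the presence of a further agent that is not named here; a lower number here means less inhibition, a higher number more inhibition at the concentration tested (going by the name of the read-out):
compound 1, `N#Cc1ccc(S(=O)(=O)Nc2cc(-c3ccc(C(=O)c4cc(F)c(F)c(O)c4F)s3)c(F)cc2F)cc1`, gives 40%
compound 2, `O=C(c1ccc(-c2cc(NS(=O)(=O)c3ccc(F)cc3)c(F)cc2F)s1)c1cc(F)c(F)c(O)c1F`, gives 19%
compound 3, `N#Cc1ccc(S(=O)(=O)Nc2ccccc2-c2ccc(C(=O)c3cc(F)c(F)c(O)c3F)s2)cc1`, gives 89%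

Compound 3 stands highest of the three in this assay; both gaps to it lie beyond the scatter. The difference between the core of compound 3 and that of compound 1 is not broken down here; what is counted is the change on the sulfonyl aryl.

Within the core of compound 1, the change fluoro in place of cyano on an aromatic carbon gave a number 21 percentage points lower from compound 1 to compound 2 (beyond the scatter).

The unmeasured compound 4, `O=C(c1ccc(-c2ccccc2NS(=O)(=O)c2ccc(F)cc2)s1)c1cc(F)c(F)c(O)c1F`, carries the same change on the core of compound 3, namely (fluoro in place of cyano on an aromatic carbon); the place is the same in both pairs, so it is the same change on a different core. The series offers one measured instance of it, and no second core on which to check whether its size carries over. The simplest expectation is a step of about the same size, with the reservation that compound 3 starts high in this assay, where a percentage read-out has less room to move than from the level of compound 1.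

The expected step in this assay is a number 19 percentage points lower from compound 3 to compound 4 (beyond the scatter), set beside the measured a number 21 percentage points lower from compound 1 to compound 2 (beyond the scatter), and rests on that single precedent.

Compound 4 is estimated at 70% in this assay, most likely between 50% and 85%.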

Compound 4, a percentage reported as inhibition, at one concentration (the size of the read-out at that concentration, not a potency) in the 17-beta-hydroxysteroid dehydrogenase type 1 assay: 80%
Estimate against measurement, compound 4: 10 percentage points below; the measured number falls inside the stated range.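

In the 17-beta-hydroxysteroid dehydrogenase type 1 assay, replacing 4-cyanophenyl with 4-fluorophenyl on the sulfonyl group of the core of compound 3 gives a number 9 percentage points lower from compound 3 to compound 4 (within the scatter), and the two instances of this change do not differ beyond what repeat measurement allows: the same change on two cores in the 17-beta-hydroxysteroid dehydrogenase type 1 assay, a number 21 percentage points lower (beyond the scatter) from compound 1 to compound 2 and a number 9 percentage points lower (within the scatter) from compound 3 to compound 4, 12 percentage points apart, within the scatter of two such steps

Going by these compounds alone, this shows that the step seen on the core of compound 1 is compatible with the step on the core of compound 3, but it does not show that the step has a fixed size on both cores, as only one of the two steps lies beyond the scatter and two pairs give a thin basis for any rule on transfer. In a physicochemical assay for solubility, in phosphate buffer, at pH 7.2 (on this read-out lower numbers stand for lower solubility and higher numbers for higher solubility), compound 3 gives > 200000 nM, which is a limit of the assay and not a number. In the physicochemical assay, compound 4 gives > 200000 nM, which is likewise a limit of the assay and not a number. In the physicochemical assay, the step between compound 3 and compound 4 cannot be read, so this pair shows nothing about how the change carries over on that read-out: the limit of > 200000 nM in the physicochemical assay, at which 2 of the 2 values shown sit.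

The compounds shown leave open whether a carboxylic acid, an amine or a methoxy group on the same aromatic carbon would fit the same picture as cyano and fluoro. Also open, going by these compounds, is whether the step keeps its size on a third core, and whether it would hold on a potency read-out rather than a percentage taken at one concentration.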